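The source may hold more compounds than are shown below. What is called first, only, known or untested is meant among the compounds shown, and "the series" means these compounds.

Measured compounds in a functional assay on MIA PaCa-2 cells (Homo sapiens) for inhibition, read by MTT assay, with a stated time of 72 h; on this read-out lower numbers stand for stronger inhibition of growth and higher numbers for weaker inhibition of growth:
- compound 1, `O=S(=O)(NCCCCCCNCc1ccc(Br)cc1)c1cc(Cl)cc(Cl)c1`: 12000 nM
- compound 2, `O=S(=O)(NCCCCCCNCc1ccc(Br)cc1)c1cccc(C(F)(F)F)c1`: 5970 nM

Compound 1 and compound 2 differ only in the group on the sulfonyl sulfur, and in this assay compound 1 and compound 2 fall within the scatter of each other, so no ordering can be drawn from the two numbers; both sit at the weak end of what this read-out resolves.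

Compound 3, `O=S(=O)(NCCCCCCNCc1ccc(Br)cc1)c1c(Cl)cccc1Cl`, has not been measured. Relative to compound 1 the change is 2,6-dichlorophenyl in place of 3,5-dichlorophenyl on a sulfonyl sulfur; the two chlorines stay on the same ring and only their arrangement differs. Among the compounds with values here, no measured pair shows this kind of rearrangement, so there is no step to lean on. The expectation is for a step from compound 1 to compound 3 of no more than the scatter, with no preferred direction, giving no change at the digits printed from compound 1 to compound 3 (within the scatter). Compound 3 is therefore expected near 12000 nM, within a range of 5000 nM to 30000 nM.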

Compound 3, concentration for 50% growth inhibition: 14700 nM
The estimate for compound 3 lay 1.2-fold (0.09 log units) below the measured number; low and high end bracket the measured number.
By their numbers in this assay, from the lowest: compounds 2, 1 and 3 (each within the scatter of the next, the first and the last beyond it).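

In this assay, the 2,6-dichlorophenyl in place of 3,5-dichlorophenyl on a sulfonyl sulfur gives a step within the scatter (a 1.2-fold higher number from compound 1 to compound 3 (0.09 log units; within the scatter)). This pair holds the atoms of the group constant, so it isolates the arrangement of the two chlorines, and for these two arrangements that arrangement does not separate the compounds on this read-out. Nothing beyond the growth numbers bears on this result.

Still open, as far as these compounds go, is whether a different group on this ring, such as an amine or a carboxylic acid in place of the chlorines, would move the number beyond the scatter. All compounds shown also share the rest of the core, so the effect of a longer chain remains unknown.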